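This account rests on a few compounds, and the source may have more. Where it says the series, first, only, none or still open, it means among the compounds named here.

Measured compounds:
compound 1 `Cc1ccc(N2CCCC2)c(C(=O)Nc2ccc(CNC(=O)OCc3cccnc3)cc2)c1`, 1650 nM
compound 2 `O=C(NCc1ccc(NC(=O)c2cccc(F)c2N2CCCC2)cc1)OCc1cccnc1`, 2020 nM

In a functional assay on HGC-27 cells (Homo sapiens) for inhibition, read by MTT assay, with a stated time of 72 h (a higher number here means a weaker inhibitor, a lower number a stronger inhibitor), compound 1 gives 1650 nM, the lowest of the two numbers; compound 2 gives 2020 nM, which lies within the usual scatter of that result, so the two cannot be ordered. Compound 3 `COc1ccc(N2CCCC2)c(C(=O)Nc2ccc(CNC(=O)OCc3cccnc3)cc2)c1` differs from compound 1 by methoxy in place of methyl on an aromatic carbon. Among the compounds with values here, no measured pair shows this change, so its step is unknown; a change of this size is expected to move the number little, if at all beyond the scatter. Compound 3 is therefore expected to give 1700 nM, between 800 nM and 3600 nM, a step of a 1.0-fold higher number from compound 1 to compound 3 (0.01 log units; within the scatter) expected to stay within the scatter.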

Compound 3, half-maximal inhibitory concentration: 138000 nM
Beside the measured number, compound 3's estimate is 81-fold (1.91 log units) below it; measured number above the stated range.
By their numbers in this assay, from the lowest: compounds 1 and 2 (each within the scatter of the next); then compound 3.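

In this assay, methoxy in place of methyl on the aromatic carbon para to a pyrrolidin-1-yl group gives an 84-fold higher number from compound 1 to compound 3 (1.92 log units; beyond the scatter) and so shows that this position is far from indifferent to a small exchange. The earlier compounds shown here offered no pair differing only here. The entering group adds one carbon-bound oxygen and one hydrogen-bond acceptor, but nothing available accounts for the size of this step.

From the compounds shown here alone, whether a hydroxyl group, an ethyl group or a chlorine atom on this carbon would stay near compound 1 or near compound 3 remains open. So does whether the same exchange elsewhere on the ring would give a step of similar size.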